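Removing one methoxy group from compound 1

The source may report more compounds than this note shows. Statements on the series, on what has been measured and on what is new or still open speak of the compounds shown alone.

Compound 1 `COc1cc(C(=O)N[C@@H]2CCC[C@@H]3CCN(C)C[C@H]32)cc(OC)c1OC`: 8.75
Compound 2 `COc1cc(C(=O)N[C@@H]2CCC[C@@H]3CCN(C)C[C@@H]32)cc(OC)c1OC`: 9.02
Compound 3 `CN1CC[C@H]2CCC[C@@H](NC(=O)c3ccc(Cl)c(Cl)c3)[C@H]2C1`: 9.05

In a physicochemical assay for acid dissociation, compound 1 gives 8.75, which lies within the scatter of the values for compound 2 and compound 3. Compound 4 `COc1ccc(C(=O)N[C@@H]2CCC[C@@H]3CCN(C)C[C@H]32)cc1OC` has not been measured yet. It puts hydrogen in place of methoxy on an aromatic carbon of compound 1 (hydrogen in place of methoxy on an aromatic carbon).

Going by the values given here, the only measured step between two closely matched compounds is a number 0.27 log units higher from compound 1 to compound 2 (within the scatter). It offers little direct guidance here, given (the fact that compounds 1 and 2 differ only in the configuration as drawn). Among the compounds with values here, no measured step removes a methoxy group, so the forecast rests on weak evidence. Still, compound 3 at 9.05 stays within the scatter of compound 1. No step beyond the scatter is therefore expected in this assay, and a higher read-out is no more likely than a lower one. The estimated change is small: a number 0.05 log units higher from compound 1 to compound 4 (within the scatter). For compound 4 the expected value is 8.8, with an estimated range from 8.45 to 9.15.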

Compound 4, acid dissociation constant: 8.89
Estimate against measurement, compound 4: 0.09 log units below; measured number inside the range.
By their numbers in this assay, from the lowest: compounds 1, 4, 2 and 3 (each within the scatter of the next).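

In this assay, hydrogen in place of methoxy gives a number 0.14 log units higher from compound 1 to compound 4 (within the scatter). Going by these compounds alone, this is the first measured change of group on the aromatic ring of this series. It shows that this aromatic carbon, ortho to a methoxy group and meta to a large group, can carry hydrogen instead of methoxy with no step beyond the scatter. Nothing measured here explains the result.

The compounds shown cover only this one replacement, so it remains open whether an amine or a carboxylic acid on this same aromatic carbon would also stay within the scatter. From the compounds shown here alone, it also remains open whether the same replacement on compound 2, which differs from compound 1 only in configuration as drawn, would give a similar result.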